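Chromone aryl ethers: side-chain amine swapped for lactam

This account rests on a few compounds, and the source may have more. Where it says the series, first, only, none or still open, it means among the compounds named here.

Measured so far in a functional assay (Homo sapiens) for antiproliferative activity, read by resazurin assay, with a stated time of 48 h, tested at 5 uM; on this read-out higher numbers stand for a stronger effect at the one concentration tested and lower numbers for a weaker effect:
- compound 1, `COc1cc(OC)c2c(=O)cc(-c3ccc(OC4CCN(C)CC4)cc3)oc2c1`, 28%
- compound 2, `COc1cc(OC)c2c(=O)cc(-c3ccc(OCCCN(C)C)cc3)oc2c1`, 36%

Among the compounds with values here, compound 2 and compound 1 lie within the scatter of each other; the only step, a number 8 percentage points higher from compound 1 to compound 2 (within the scatter), exchanges one basic side chain for another. Compound 3, `COc1cc(OC)c2c(=O)cc(-c3ccc(OCCN4CCCC4=O)cc3)oc2c1`, brings (2-oxopyrrolidin-1-yl in place of (dimethylamino)methyl on a saturated chain carbon, two bonds along the chain from an oxygen on an aromatic ring). Within the data shown here, no measured step covers an exchange of a basic amine for a lactam, so nothing here points to a shift beyond the scatter. Compound 3 is estimated at 30%, range 15% to 45%, which is expected to be a number 6 percentage points lower from compound 2 to compound 3 (within the scatter).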

Compound 3, a percentage reported as inhibition, at one concentration (the size of the read-out at that concentration, not a potency): 7%
Compound 3: middle estimate off by 23 percentage points, on the high side; measured number below the stated range.
By their numbers in this assay, from the lowest: compound 3; then compounds 1 and 2 (each within the scatter of the next).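

In this assay the side chain on the oxygen on an aromatic ring is not interchangeable: 2-oxopyrrolidin-1-yl in place of (dimethylamino)methyl gives a number 29 percentage points lower from compound 2 to compound 3 (beyond the scatter) and 2-(2-oxopyrrolidin-1-yl)ethyl in place of 1-methylpiperidin-4-yl gives a number 21 percentage points lower from compound 1 to compound 3 (beyond the scatter) with both steps beyond the scatter. Within the data shown here, the exchange between the two amine side chains stayed within the scatter, so the lactam is the first change here to move this read-out. Nothing available bears on the cause.

Still open, from the compounds shown here alone, is whether the drop follows the lactam carbonyl or the ring itself, which a plain pyrrolidine on the same chain would address. The chain is also not separated from the end group, and 3-(2-oxopyrrolidin-1-yl)propyl would address that.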